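Extending the acetamide of compound 2 by one carbon

The source may hold more compounds than are shown below. What is called first, only, known or untested is meant among the compounds shown, and "the series" means these compounds.

The series is built on a shared sulfonate core with an isopropyl group on one ring and an amide on the other. In a functional assay on MCF7 cells (Homo sapiens) for antiproliferative activity, read by sulforhodamine B assay, with a stated time of 48 h (on this read-out higher numbers stand for weaker inhibition and lower numbers for stronger inhibition), compound 1 `CCC(=O)Nc1cccc(S(=O)(=O)Oc2ccccc2C(C)C)c1` gives 14000 nM, compound 2 `CC(=O)Nc1ccc(S(=O)(=O)Oc2ccccc2C(C)C)cc1` gives 16000 nM, and compound 3 `CC(=O)Nc1ccc(S(=O)(=O)Oc2ccccc2I)cc1` gives 27000 nM. Compound 2 therefore stands second highest of the three numbers, with compound 1 nearest and compound 3 furthest, and both gaps lie within the scatter of this assay. Among the measured compounds shown here, the only single step that has been measured, a 1.7-fold higher number from compound 2 to compound 3 (0.23 log units; within the scatter), concerns the substituent on the ring that carries the sulfonate oxygen and does not touch the amide.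

Compound 4 `CCC(=O)Nc1ccc(S(=O)(=O)Oc2ccccc2C(C)C)cc1` arises from compound 2 through (methyl in place of hydrogen on a saturated chain carbon bound to a carbonyl carbon). For the measured compounds named here, no measured step follows this change, so nothing bears directly on it; the closest hint is that compound 1, which also carries a propanoylamino group, and compound 2 sit within the scatter of each other. On that basis the step from compound 2 to compound 4 is expected to be small, with no direction beyond the scatter, namely a 1.1-fold lower number from compound 2 to compound 4 (0.03 log units; within the scatter). Compound 4 is accordingly estimated at 15000 nM, between 7000 nM and 32000 nM, in this assay.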

Compound 4, half-maximal inhibitory concentration: 11000 nM
For compound 4 the middle estimate is 1.4-fold (0.13 log units) above the measured one; low and high end bracket the measured number.
By their numbers in this assay, from the lowest: compounds 4, 1, 2 and 3 (each within the scatter of the next, the first and the last beyond it).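

Among the compounds shown here, with this pair, the amide chain itself is changed for the first time, whereas the only earlier single step concerned the substituent on the ring that carries the sulfonate oxygen. Replacing a hydrogen with methyl on the saturated chain carbon bound to the carbonyl carbon turns acetamido into propanoylamino and gives a 1.5-fold lower number from compound 2 to compound 4 (0.16 log units; within the scatter) in this assay, so this one added carbon does not separate the two compounds on this read-out. The pair therefore shows that, with the isopropyl group held constant, the assay tolerates either acetamido or propanoylamino at this place, but no measurement of any other property accompanies the step, and the data offer no explanation for it.

The compounds shown leave open whether a longer chain, such as butanoyl, or a chain ending in an amine or a carboxylic acid, would move the number beyond the scatter from that of compound 2. They also leave open whether propanoylamino would behave the same way alongside the iodo group of compound 3, since that single change is shown here only with isopropyl in place.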